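This account rests on a few compounds, and the source may have more. Where it says the series, first, only, none or still open, it means among the compounds named here.

Working notes on the series, read throughout in a functional assay on cells (Erythrocyte, Homo sapiens) for inhibition, read by spectrophotometry and hemolysis, with a stated time of 10 min; on this read-out higher numbers stand for weaker inhibition and lower numbers for stronger inhibition. Within the data shown here, compound 2 (`O=C(CCc1nc2ccccc2c(=O)[nH]1)N/N=C/c1ccc([N+](=O)[O-])cc1`) gives 54000000 nM as the lowest of the three numbers so far. Compound 1 (`O=C(CCc1nc2ccccc2c(=O)[nH]1)N/N=C/c1ccc(O)c(O)c1`) gives 255000000 nM and compound 3 (`COc1cc(/C=N/NC(=O)CCCc2nc3ccccc3c(=O)[nH]2)cc(OC)c1OC`) gives 613000000 nM as higher numbers, both beyond the scatter from compound 2. Next is compound 4 (`O=C(CCc1nc2ccccc2c(=O)[nH]1)N/N=C/c1ccc(Cl)cc1`), with chloro in place of nitro on an aromatic carbon, para to a large group (chloro in place of nitro on an aromatic carbon). Among the measured compounds shown here, one measured step bears on this change: 4-nitrophenyl in place of 3,4-dihydroxyphenyl gave a 4.7-fold lower number from compound 1 to compound 2 (0.67 log units; beyond the scatter) as a modest difference. For the measured compounds named here, no measured compound carries chloro, so this single step sets only a rough scale. With compound 2 at 54000000 nM at the low end of the numbers, a modest step toward a higher number is expected in this assay for this swap. The estimated change is a 2.2-fold higher number from compound 2 to compound 4 (0.35 log units; beyond the scatter) in size. Compound 4 is expected at 120000000 nM within an estimated range from 35000000 nM to 350000000 nM for now.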

Compound 4, half-maximal inhibitory concentration: 84000000 nM
For compound 4 the middle estimate is 1.4-fold (0.15 log units) above the measured one, and the stated range covers the measured number.
By their numbers in this assay, from the lowest: compounds 2 and 4 (each within the scatter of the next); then compound 1; then compound 3.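

At the aromatic carbon para to a large group, chloro in place of nitro gives a 1.6-fold higher number from compound 2 to compound 4 (0.19 log units; within the scatter) in this assay, so this change, with 3 heavy atoms leaving and 1 entering and 2 hydrogen-bond acceptors lost, does not separate the two compounds. The change from 3,4-dihydroxyphenyl to 4-chlorophenyl gives a 3.0-fold lower number from compound 1 to compound 4 (0.48 log units; beyond the scatter), so a second group, alongside 4-nitrophenyl, stands beyond the scatter from compound 1. No measurement at hand accounts for either step.

Going by these compounds, whether an amine or a carboxylic acid at this same place would stay with nitro and chloro remains open. Compound 3 differs from the others in both its chain and its ring groups, so the contribution of each stays unseparated.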